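The source may hold more compounds than are shown below. What is called first, only, known or untested is meant among the compounds shown, and "the series" means these compounds.

Compound 1 `CCCOC(=O)/C=C/c1ccc(OS(=O)(=O)c2ccc(Cl)cc2)c(OC)c1`, giving 150000 nM in a toxicity assay on L02 cells (Homo sapiens) for cytotoxicity, read by MTT assay, with a stated time of 24 h; a lower number here means that less compound is tolerated, a higher number that more compound is tolerated. Compound 2 `CCCCS(=O)(=O)Oc1ccc(/C=C/C(=O)OC)cc1OC`, giving 208000 nM. Compound 3 `CCCCS(=O)(=O)Oc1ccc(/C=C/C(=O)Nc2ccc(C)cc2)cc1OC`, giving 26800 nM.

Compound 1 stands second highest of these three numbers in this assay; its value and that of compound 2 lie within the scatter of each other, while compound 3 sits beyond the scatter below it. Compound 4 `COc1cc(/C=C/C(=O)Nc2ccc(I)cc2)ccc1OS(=O)(=O)c1ccc(Cl)cc1` differs from compound 1 by (4-iodophenyl)amino in place of propoxy on a carbonyl carbon. Going by the values given here, one measured step bears on this change: a 7.8-fold lower number from compound 2 to compound 3 (0.89 log units; beyond the scatter), where methoxy gave way to (4-methylphenyl)amino on a carbonyl carbon. Since that step was modest but beyond the scatter, a downward step of comparable size is expected here, a 7.5-fold lower number from compound 1 to compound 4 (0.88 log units; beyond the scatter). Compound 4 is therefore estimated at 20000 nM, with a range from 7000 nM to 55000 nM.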

Compound 4, half-maximal cytotoxic concentration: 39400 nM
For compound 4 the middle estimate is 2.0-fold (0.29 log units) below the measured one, within the range that was stated.
By their numbers in this assay, from the lowest: compounds 3 and 4 (each within the scatter of the next); then compounds 1 and 2 (each within the scatter of the next).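

In this assay, (4-iodophenyl)amino in place of propoxy on a carbonyl carbon gives a 3.8-fold lower number from compound 1 to compound 4 (0.58 log units; beyond the scatter). The earlier downward step with (4-methylphenyl)amino in place of methoxy, a 7.8-fold lower number from compound 2 to compound 3 (0.89 log units; beyond the scatter), therefore recurs beyond the scatter with a different ester, a different aryl group and a different sulfonyl partner. Nothing shown here accounts for either step. The compounds shown leave open whether the iodine contributes to the step or the amide link alone carries it, a question that plain phenylamino or propylamino on the same carbonyl carbon would address.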